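Replacing 4-Cyanophenyl with 2,3,5-Trifluorophenyl on the Shared Core

This account rests on a few compounds, and the source may have more. Where it says the series, first, only, none or still open, it means among the compounds named here.

Three compounds have been measured in a functional assay with Homo sapiens as the target; on this read-out higher numbers stand for weaker inhibition and lower numbers for stronger inhibition:
compound 1, `CC(C)[C@H](NC(=O)COc1cccc2ccccc12)C(=O)N[C@@H](CC(=O)O)C(=O)COc1ccc(C#N)cc1`, gives 26700 nM;
compound 2, `CC(C)[C@H](NC(=O)COc1cccc2ccccc12)C(=O)N[C@@H](CC(=O)O)C(=O)COc1cccc(F)c1`, gives 12000 nM;
compound 3, `CC(C)[C@H](NC(=O)COc1cccc2ccccc12)C(=O)N[C@@H](CC(=O)O)C(=O)COc1ccc(F)c(F)c1F`, gives 20600 nM.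

Compound 1 stands at the highest of these three numbers. Its nearest neighbour is compound 3, with a 1.3-fold lower number from compound 1 to compound 3 (0.11 log units; within the scatter), and its furthest is compound 2, with a 2.2-fold lower number from compound 1 to compound 2 (0.35 log units; beyond the scatter). Between the two fluorinated analogues the gap is a 1.7-fold higher number from compound 2 to compound 3 (0.23 log units; within the scatter).

Compound 4, `CC(C)[C@H](NC(=O)COc1cccc2ccccc12)C(=O)N[C@@H](CC(=O)O)C(=O)COc1cc(F)cc(F)c1F`, is not yet measured. It differs from compound 1 in one place: 2,3,5-trifluorophenyl in place of 4-cyanophenyl on an oxygen on a saturated carbon. Within the data shown here, the steps that bear on this change are those from compound 1 to its fluorinated analogues: a single fluorine gave a modest lowering beyond the scatter, while three fluorines on the 2,3,4-trifluorophenyl pattern gave only a lowering within the scatter. A trifluorophenyl pattern is again entering here, so the expected step in this assay is a small lowering, a 1.5-fold lower number from compound 1 to compound 4 (0.17 log units; within the scatter), likely within or just at the edge of the scatter. On that basis compound 4 is estimated at 18000 nM, with a range from 8000 nM to 40000 nM.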

Compound 4, half-maximal inhibitory concentration: 11200 nM
Compound 4: middle estimate off by 1.6-fold (0.21 log units), on the high side; measured number inside the range.
By their numbers in this assay, from the lowest: compounds 4, 2, 3 and 1 (each within the scatter of the next, the first and the last beyond it).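

In this assay the change to 2,3,5-trifluorophenyl on the oxygen gives a step that clears the scatter, a 2.4-fold lower number from compound 1 to compound 4 (0.38 log units; beyond the scatter), whereas the earlier 2,3,4-trifluorophenyl step from the same 4-cyanophenyl compound did not. Even so, the two trifluorophenyl patterns cannot be told apart here, since a 1.8-fold lower number from compound 3 to compound 4 (0.26 log units; within the scatter) stays within the scatter. Three fluorines also cannot be separated from the single fluorine of 3-fluorophenyl, as a 1.1-fold lower number from compound 2 to compound 4 (0.03 log units; within the scatter) also stays within the scatter.

The data shown offer no measurement that accounts for these steps. From the compounds shown here alone, how a chlorophenyl, a methoxyphenyl or a pyridyl group on this oxygen would compare with the fluorinated rings remains open, so the reach of this trend beyond these four compounds is unknown.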